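The source may report more compounds than this note shows. Statements on the series, on what has been measured and on what is new or still open speak of the compounds shown alone.

Compound 1 `COc1ccc(/C=C/C(=O)c2ccc(OC)c3c2OC(C)(C)C=C3)cc1OCC=C(C)C` is measured in a functional assay on A-375 cells (Homo sapiens) for cytotoxicity, read by MTT assay (a higher number here means a weaker inhibitor, a lower number a stronger inhibitor), where compound 1 reaches only the limit > 10000 nM, a limit of the assay rather than a number, and so compound 1 stands at the limit of > 10000 nM in this assay, at which 1 of the 3 values shown sits, with no finished value of its own. Two near relatives replace the same group on the same oxygen with an acyl group. Compound 2 `C=CC(=O)Oc1cc(/C=C/C(=O)c2ccc(OC)c3c2OC(C)(C)C=C3)ccc1OC` gives 390 nM in this assay, and compound 3 `COc1ccc(/C=C/C(=O)c2ccc(OC)c3c2OC(C)(C)C=C3)cc1OC(=O)C1CC1` gives 380 nM. The step of an at least 25-fold lower number from compound 1 to compound 2 (1.40 log units; beyond the scatter) and the step of an at least 26-fold lower number from compound 1 to compound 3 (1.42 log units; beyond the scatter) both run in the same direction, and the step of a 1.0-fold lower number from compound 2 to compound 3 (0.01 log units; within the scatter) shows that the two acyl groups lead to the same place.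

Compound 4 `COc1ccc(/C=C/C(=O)c2ccc(OC)c3c2OC(C)(C)C=C3)cc1OC(=O)c1ccc(Br)cc1` differs from compound 1 in the same position: (4-bromophenyl)carbonyl in place of 3-methylbut-2-en-1-yl on an oxygen on an aromatic ring. Since the two measured steps from compound 1 to an acyl derivative, an at least 25-fold lower number from compound 1 to compound 2 (1.40 log units; beyond the scatter) and an at least 26-fold lower number from compound 1 to compound 3 (1.42 log units; beyond the scatter), were both large and in the same direction, the step from compound 1 to compound 4 is expected to be large in this assay as well, in the same direction, as an at least 20-fold lower number from compound 1 to compound 4 (1.30 log units; beyond the scatter). Compound 4 is therefore estimated at 500 nM in this assay, within a range of 150 nM to 3000 nM.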

Compound 4, half-maximal inhibitory concentration: 420 nM
Compound 4: middle estimate off by 1.2-fold (0.08 log units), on the high side; the range from low to high includes it.
By their numbers in this assay, from the lowest: compounds 3, 2 and 4 (each within the scatter of the next). At a limit, above all of these: compound 1.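

In this assay, compound 4 shows that the acyl gain on this oxygen also holds for a (4-bromophenyl)carbonyl group, which brings a six-membered aromatic ring, with a large step (an at least 23-fold lower number from compound 1 to compound 4 (1.37 log units; beyond the scatter)). Compound 4 cannot be told apart from the two compounds with non-aromatic acyl groups (a 1.1-fold higher number from compound 3 to compound 4 (0.04 log units; within the scatter); a 1.1-fold higher number from compound 2 to compound 4 (0.03 log units; within the scatter)), so vinyl, cyclopropyl and 4-bromophenyl on the carbonyl carbon all lead to the same place. The large step is only a bound, and compound 1 gives a limit rather than a number: the limit of > 10000 nM in this assay, at which 1 of the 4 values shown sits.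

Compound 1 is the only ether shown, so it stays open whether a methyl ether or a free hydroxyl on this oxygen would behave like compound 1 or like the acyl compounds. From the compounds shown here alone, whether a carbamate bearing an amine, or an acyl group carrying a carboxylic acid, would fit the same pattern also remains open.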